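A few compounds are considered here, and "the series" means these few. Any claim that something is new, unique, unknown or untested is made for them only; others in the source may bear on it.

Measured compounds in a functional assay on MGC-803 cells (Homo sapiens) for inhibition, read by MTT assay, with a stated time of 72 h; on this read-out higher numbers stand for weaker inhibition and lower numbers for stronger inhibition:
- compound 1, `Cc1ccc(-n2cc(CNC(=O)c3cccc4c3cnn4C(C)C)nn2)cc1C`: > 40000 nM
- compound 2, `CC(C)n1ncc2c(C(=O)NCc3cn(-c4ccc([N+](=O)[O-])cc4)nn3)cccc21`: > 40000 nM

Compound 1 stands at the edge of what this assay reports. In this assay compound 1 gives > 40000 nM, which is a limit of the assay and not a number. Compound 2 gives > 40000 nM in this assay, again a limit rather than a number. Going by the values given here, the single measured step, a step that the two limits leave unreadable from compound 1 to compound 2, therefore cannot be sized; both of its ends sit at the limit of > 40000 nM in this assay, at which 2 of the 2 values shown sit, so the change from 3,4-dimethylphenyl to 4-nitrophenyl on the aromatic nitrogen tells nothing about how much either compound actually inhibits.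

Compound 3, `Cc1ccccc1-n1cc(CNC(=O)c2cccc3c2cnn3C(C)C)nn1`, is the unmeasured compound. Its change from compound 1 is 2-methylphenyl in place of 3,4-dimethylphenyl on an aromatic nitrogen. Among the compounds with values here, no measured step bears on this change in a readable way; the only comparison available, from compound 1 to compound 2, is hidden by the limit. Given that both measured compounds reach only a limit, compound 3 is expected to remain at the limit as well, with no step beyond the scatter in either direction. The estimated step is a step that the limit leaves unreadable from compound 1 to compound 3. For compound 3 the estimate in this assay is 60000 nM, within a range from 25000 nM to 200000 nM, and most likely the assay will again report only a limit.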

Compound 3, half-maximal inhibitory concentration: > 40000 nM
Compound 3 ended at the assay's limit; the forecaster's own chance of this, stated with the estimate: 85%; the middle value is on the limit's open side.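

In this assay compound 3 gives > 40000 nM as a limit of the assay and not a number. No step from compound 1 or compound 2 to compound 3 can be read, since all three compounds end at the same edge: the limit of > 40000 nM in this assay, at which 3 of the 3 values shown sit.

The compounds shown leave open how strongly any of them inhibits and whether the group on the aromatic nitrogen matters at all.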